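A few compounds are considered here, and "the series" means these few. Any claim that something is new, unique, unknown or untested is made for them only; others in the source may bear on it.

Working notes on the series, all read in a functional assay on K562 cells (Homo sapiens) for cytotoxicity, read by trypan blue exclusion, with a stated time of 96 h; a lower number here means a stronger inhibitor, a higher number a weaker inhibitor. Compound 1 (`COc1ccc(CS(=O)(=O)/C=C/c2ccccc2OC)cc1N`) gives 7500 nM and compound 2 (`COc1cc(OC)c(/C=C/S(=O)(=O)Cc2ccc(OC)cc2[N+](=O)[O-])c(OC)c1`) gives 20000 nM. Compound 3 (`COC(=O)CCNc1cc(CS(=O)(=O)/C=C/c2c(OC)cc(OC)cc2OC)ccc1OC`) gives 1000 nM, the lowest of the three numbers and beyond the scatter of both others. Compound 4 (`COC(=O)C(Nc1cc(CS(=O)(=O)/C=C/c2c(OC)cc(OC)cc2OC)ccc1OC)c1ccc(F)cc1`) carries (4-fluorophenyl)(methoxycarbonyl)methyl in place of 2-(methoxycarbonyl)ethyl on a nitrogen on an aromatic ring. Going by the values given here, no two measured compounds differ in one place only, so the expectation has no direct precedent and stays wide. The expected step, a 2.5-fold lower number from compound 3 to compound 4 (0.40 log units; beyond the scatter), is a modest fall in the number, only slightly beyond the scatter. For compound 4 the estimated value is 400 nM, with an expected range from 70 nM to 2500 nM.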

Compound 4, half-maximal inhibitory concentration: 800 nM
Compound 4: the middle estimate sits 2.0-fold (0.30 log units) below what was measured; the range from low to high includes it.
By their numbers in this assay, from the lowest: compounds 4 and 3 (each within the scatter of the next); then compound 1; then compound 2.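

In this assay, going by these compounds alone, the step of a 1.3-fold lower number from compound 3 to compound 4 (0.10 log units; within the scatter) is the first comparison between compounds that differ in one place. On a nitrogen on an aromatic ring, (4-fluorophenyl)(methoxycarbonyl)methyl reads the same as 2-(methoxycarbonyl)ethyl, so this position accepts the added six-membered aromatic ring with no change in the number beyond the scatter. No evidence bears on why the two groups read alike.

Still open, on these data alone, is how a carboxylic acid or an amide in place of the methyl ester would read on this nitrogen. Also open, as far as these compounds go, is whether a plain phenyl without the fluorine would read the same.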